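From compound 3 to compound 4: one group exchanged

The source may hold more compounds than are shown below. What is called first, only, known or untested is meant among the compounds shown, and "the series" means these compounds.

Measured in an ADME assay for permeability, using PAMPA, at pH 7.4; a lower number here means that the compound crosses the layer more slowly, a higher number that the compound crosses the layer faster:
- Compound 1 `COc1ccc(-c2nc3ccccc3s2)cc1NC(=O)c1cc([N+](=O)[O-])ccc1Cl`: "below limit of detection" (no number reported)
- Compound 2 `COc1ccc(-c2nc3ccccc3s2)cc1NC(=O)c1cc([N+](=O)[O-])c(N2CCC(C(=O)O)CC2)cc1Cl`: 5 10^-6 cm/s
- Compound 3 `COc1ccc(-c2nc3ccccc3s2)cc1NC(=O)c1cc([N+](=O)[O-])c(N2CCN(C)CC2)cc1Cl`: 676 10^-6 cm/s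

Compound 3 holds the higher of the two numbers, 676 10^-6 cm/s. Among the compounds with values here, the only measured step that bears on the next change is large and beyond the scatter: a 140-fold higher number from compound 2 to compound 3 (2.13 log units; beyond the scatter). Compound 4 `COC(=O)C1CCN(c2cc(Cl)c(C(=O)Nc3cc(-c4nc5ccccc5s4)ccc3OC)cc2[N+](=O)[O-])CC1` changes the same aromatic carbon: 4-(methoxycarbonyl)piperidin-1-yl in place of 4-methylpiperazin-1-yl on an aromatic carbon. Its entering group is the methyl ester of the 4-carboxypiperidin-1-yl group in compound 2. A fall in this assay is therefore expected, smaller than that large step, but one step cannot fix its size. The expected change is a 6.8-fold lower number from compound 3 to compound 4 (0.83 log units; beyond the scatter). For compound 4 the estimate is 100 10^-6 cm/s, with an expected range from 12 10^-6 cm/s to 600 10^-6 cm/s.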

Compound 4, apparent permeability: < 1 10^-6 cm/s
Compound 4 was reported as a limit; the forecaster's own chance of this, stated with the estimate: 25%; middle value at least 100-fold (2.00 log units) from the limit.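

In this assay, 4-(methoxycarbonyl)piperidin-1-yl on this aromatic carbon gives an at least 670-fold lower number from compound 3 to compound 4 (2.82 log units; beyond the scatter), so the high number does not survive this exchange. The earlier compounds shown here could not show what capping the acid does, and methyl on that oxygen gives an at least 5.0-fold lower number from compound 2 to compound 4 (0.69 log units; beyond the scatter), so the number falls rather than rises. The value for compound 4 is a limit, not a number: the limit of < 1 10^-6 cm/s in this assay, at which 1 of the 4 values shown sits. From the compounds shown here alone, how far compound 4 lies past that limit stays open. So does whether the high number follows the ring nitrogen of compound 3, which an unsubstituted piperidine or a morpholine ring on this carbon could help to test.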